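The compounds below may be only part of what the source reports. "The series", "measured", "known", "first", "only" and "open" are said of these compounds alone.

Compound 1 `Cc1cc(C)c(NC(=O)N(Cc2ccc(-c3nnc(C)o3)cc2)C2CCCCCC2)c(C)c1` gives 27 nM in an assay on microsomes from intestine for inhibition of acyl-CoA:cholesterol acyltransferase (Oryctolagus cuniculus) (on this read-out lower numbers stand for stronger inhibition and higher numbers for weaker inhibition), the higher of the two numbers recorded so far. Among the measured compounds shown here, compound 2 `CN(C)c1ccc(CN(Cc2cccc(-c3cc[nH]n3)c2)C(=O)Nc2c(F)cc(F)cc2F)cc1`, which carries the 1H-pyrazol-3-yl group on an unrelated core, gives 12 nM in this assay; the two differ in more than one place, so no single step is drawn from them. Compound 3 `Cc1cc(C)c(NC(=O)N(Cc2ccc(-c3cc[nH]n3)cc2)C2CCCCCC2)c(C)c1` follows compound 1 with one change: 1H-pyrazol-3-yl in place of 5-methyl-1,3,4-oxadiazol-2-yl on an aromatic carbon. For the measured compounds named here, with no measured step for this change, the step from compound 1 to compound 3 is expected to be small, a 1.4-fold lower number from compound 1 to compound 3 (0.13 log units; within the scatter), in the direction of a lower number. Compound 3 is estimated at 20 nM, within 7 nM to 60 nM.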

Compound 3, half-maximal inhibitory concentration: 52 nM
For compound 3 the middle estimate is 2.6-fold (0.41 log units) below the measured one; the range from low to high includes it.
By their numbers in this assay, from the lowest: compound 2; then compounds 1 and 3 (each within the scatter of the next).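

Here the exchange gives a 1.9-fold higher number from compound 1 to compound 3 (0.28 log units; within the scatter) in this assay, so on this aromatic carbon, para to a large group, the two five-membered aromatic rings cannot be told apart. On the shared core, the ring with 1 hydrogen-bond donor and 1 hydrogen-bond acceptor thus stands level with the ring with 0 donors and 3 acceptors. No measurement at hand bears on the reason for this result. Open, from the compounds shown here alone, is whether a group outside this ring type, such as a carboxylic acid or a dimethylamino group, holds up at this position.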